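This account rests on a few compounds, and the source may have more. Where it says the series, first, only, none or still open, it means among the compounds named here.

Measured so far in an assay on membranes from brain for displacement of a labelled ligand from adenosine receptor A1 (Rattus norvegicus); a higher number here means a weaker inhibitor, a lower number a stronger inhibitor:

Compound 1 `Cn1c(=O)c2c(ncn2C2O[C@H](CO)[C@@H](O)[C@H]2O)n(C)c1=O` gives 2700 nM.
Compound 2 `CCCCCn1c(=O)c2c(ncn2C2O[C@H](CO)[C@@H](O)[C@H]2O)n(CCCCC)c1=O` gives 8790 nM.
Compound 3 `CCCCn1c(=O)c2c(ncn2C2O[C@H](C(N)=O)[C@@H](O)[C@H]2O)n(CCCC)c1=O` gives 3060 nM.

All three share one core, and they differ in the two chains attached to it and in the group on a saturated ring carbon of the five-membered non-aromatic ring with one oxygen. Among the three numbers, compound 3 sits second highest. Its nearest neighbour is compound 1, and the two lie within the usual scatter, so they cannot be told apart. Compound 2 stands furthest away, with a higher number than compound 3, and that gap is beyond the scatter.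

Compound 4 `CCCCn1c(=O)c2c(ncn2C2O[C@H](OC(C)=O)[C@@H](O)[C@H]2O)n(CCCC)c1=O` has not yet been tested. It keeps the two butyl chains of compound 3 and changes only one spot: acetoxy in place of carbamoyl on a saturated ring carbon. Among the compounds with values here, no pair of measured compounds isolates this change, so the expected size of the step rests on judgement rather than on a measured precedent. A modest rise in the number, that is a somewhat weaker inhibitor, seems the more likely outcome, though a result within the scatter of compound 3 cannot be ruled out. Compound 4 is therefore expected to give about 8000 nM, within a range from 2500 nM to 25000 nM. The expected step is a 2.6-fold higher number from compound 3 to compound 4 (0.42 log units; beyond the scatter).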

Compound 4, inhibition constant: 3720 nM
Estimate against measurement, compound 4: 2.2-fold (0.33 log units) above; the range from low to high includes it.
By their numbers in this assay, from the lowest: compounds 1, 3 and 4 (each within the scatter of the next); then compound 2.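

In this assay, putting acetoxy in place of carbamoyl on a saturated ring carbon, next to the ring oxygen, gives a 1.2-fold higher number from compound 3 to compound 4 (0.08 log units; within the scatter), so compound 3 and compound 4 cannot be told apart. Within the data shown here, this is the first comparison here in which only one place differs, and it shows that this particular exchange, with the two butyl chains kept, leaves no readable mark on the result, even though the groups differ in their counts: carbamoyl has one hydrogen-bond donor and one acceptor, while acetoxy has no donor and two acceptors. No measurement shown explains why the two compounds cannot be told apart.

On these data alone, one exchange between two groups cannot show how much this position tolerates in general, so it remains open whether an amine or a carboxylic acid on this ring carbon would give a number beyond the scatter of compound 3. As far as these compounds go, it also remains open whether the same exchange would again leave the two compounds indistinguishable if the butyl chains were replaced by a longer chain.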